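Phenyl for pentyl on a chain bound to an aryl oxygen

A few compounds are considered here, and "the series" means these few. Any claim that something is new, unique, unknown or untested is made for them only; others in the source may bear on it.

Compound 1, `CC(C)COc1ccc2c(Cl)ccnc2c1`, gives 2100 nM in a functional assay on NCI-H1650 cells (Homo sapiens) for cytotoxicity, read by MTT assay, with a stated time of 48 h; a lower number here means a stronger inhibitor, a higher number a weaker inhibitor.
Compound 2, `CCCCCCCCOc1ccc2c(Cl)ccnc2c1`, gives 3240 nM in this assay.
Compound 3, `Clc1ccnc2cc(OCc3ccccc3)ccc12`, gives 2720 nM in this assay.

Compound 2 carries the highest of the three numbers, but its gaps to compound 3 and to compound 1 are both within the scatter, so the three stand together. Compound 4, `Clc1ccnc2cc(OCCCc3ccccc3)ccc12`, differs from compound 2 by phenyl in place of pentyl on a saturated chain carbon, three bonds along the chain from an oxygen on an aromatic ring. Among the compounds with values here, the one measured step of related kind, a 1.3-fold higher number from compound 1 to compound 3 (0.11 log units; within the scatter), stayed within the scatter, and no measured pair sets pentyl against phenyl at this place. Compound 4 is therefore expected to give 2700 nM in this assay, with a range from 1300 nM to 5600 nM. The expected step is a 1.2-fold lower number from compound 2 to compound 4 (0.08 log units; within the scatter), nothing beyond the scatter.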

Compound 4, half-maximal inhibitory concentration: 630 nM
Estimate against measurement, compound 4: 4.3-fold (0.63 log units) above, and the stated range ends above it.
By their numbers in this assay, from the lowest: compound 4; then compounds 1, 3 and 2 (each within the scatter of the next).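

In this assay, phenyl in place of pentyl on this saturated chain carbon gives a 5.1-fold lower number from compound 2 to compound 4 (0.71 log units; beyond the scatter), the only step among these compounds that lies beyond the scatter. Within the data shown here, the far end of the chain on the aromatic oxygen therefore can change the number, which the earlier compounds, standing together, did not show. Nothing available here bears on why this step occurs. The compounds shown leave open whether a cyclohexyl ring would do the same as phenyl at this place. They also leave open what an amine or a carboxylic acid on that phenyl would do.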